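The compounds below may be only part of what the source reports. "The series", "measured", "known", "first", "only" and "open" are said of these compounds alone.

Series notes.

In an ADME assay on cells (Mus musculus, strain BALB/C) for cytotoxicity, read by MTT assay, with a stated time of 24 h; on this read-out lower numbers stand for higher toxicity in this test and higher numbers for lower toxicity in this test: compound 1 `Cc1ccc(C(=O)N/N=C/c2ccccc2)c(O)c1` gives 578000 nM; compound 2 `Cc1ccc(C(=O)N/N=C/c2ccccc2O)c(O)c1` gives 761000 nM; compound 3 `Cc1ccc(C(=O)N/N=C/c2cc(Cl)ccc2O)c(O)c1` gives 560000 nM.

Compound 4 `Cc1ccc(C(=O)N/N=C/c2cccc(Cl)c2)c(O)c1` is not yet measured. From compound 3 to compound 4 the change is hydrogen in place of hydroxy on an aromatic carbon. The same kind of change has already been made once, from compound 2 to compound 1, (hydrogen in place of hydroxy on an aromatic carbon), where the step was a 1.3-fold lower number from compound 2 to compound 1 (0.12 log units; within the scatter). The two place lines are not identical: in the change to compound 4 the site is also para to a chloro group. The cores differ by chloro in place of hydrogen on an aromatic carbon, with the step of a 1.4-fold lower number from compound 2 to compound 3 (0.13 log units; within the scatter). Both recorded steps lie within the scatter, so a step of similar size is expected for compound 4 in this assay, resting on the earlier step of a 1.3-fold lower number from compound 2 to compound 1 (0.12 log units; within the scatter) from compound 2 to compound 1. The expected step is a 1.3-fold lower number from compound 3 to compound 4 (0.11 log units; within the scatter). Compound 4 is estimated at 430000 nM, with the range 250000 nM to 750000 nM.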

Compound 4, half-maximal cytotoxic concentration: 636000 nM
Compound 4: middle estimate off by 1.5-fold (0.17 log units), on the low side; the range from low to high includes it.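

In this assay, hydrogen in place of hydroxy gives a 1.1-fold higher number from compound 3 to compound 4 (0.06 log units; within the scatter), and this agrees with the earlier step: the same change on two cores in this assay, a 1.3-fold lower number (0.12 log units; within the scatter) from compound 2 to compound 1 and a 1.1-fold higher number (0.06 log units; within the scatter) from compound 3 to compound 4, 1.5-fold (0.17 log units) apart, within the scatter of two such steps

Chloro in place of hydrogen gives a 1.1-fold higher number from compound 1 to compound 4 (0.04 log units; within the scatter), and this also agrees with the earlier step: the same change on two cores in this assay, a 1.4-fold lower number (0.13 log units; within the scatter) from compound 2 to compound 3 and a 1.1-fold higher number (0.04 log units; within the scatter) from compound 1 to compound 4, 1.5-fold (0.17 log units) apart, within the scatter of two such steps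

Each change thus carries between the two cores without a gap beyond the scatter, but as every step lies within the scatter, this shows no measurable effect that transfers and does not show how either change would behave on a further core.

Still open, going by these compounds, is whether other groups on the aromatic ring, such as an amine, a carboxylic acid or a methoxy group, would move the number beyond the scatter. Also open, on these data alone, is whether a longer chain in place of the methyl group on the shared core would do so.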